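This account rests on a few compounds, and the source may have more. Where it says the series, first, only, none or still open, it means among the compounds named here.

In an ADME assay on microsomes from liver (Rattus norvegicus) for metabolic stability (on this read-out higher numbers stand for a longer-lived compound and lower numbers for a shorter-lived compound), compound 2 (`CC(C)C(Nc1nccs1)c1ccc(-c2ccc3cccc(F)c3c2)[nH]c1=O`) gives 0.07 h, the lower of the two actual numbers available. Compound 3 (`CC(C)[C@@H](C[C@H]1CCNC1=O)c1ccc(-c2ccc3cccc(F)c3c2)[nH]c1=O`) gives 0.507 h, a higher number by more than the usual scatter. Compound 1 (`CCn1ncc2c(F)cc(-c3ccc(C(CC)(CC)c4nncn4C)c(=O)[nH]3)cc21`) gives > 3 h, which is a limit of the assay and not a number.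

Compound 4 (`CC(C)C(CC(N)=O)c1ccc(-c2ccc3cccc(F)c3c2)[nH]c1=O`) has not yet been measured. Its structure departs from that of compound 2 in one place: carbamoylmethyl in place of (1,3-thiazol-2-yl)amino on a saturated chain carbon bound to an aromatic carbon and a saturated chain carbon. Carbamoylmethyl stands in place of (1,3-thiazol-2-yl)amino on a saturated chain carbon bound to an aromatic carbon and a saturated chain carbon.

For the measured compounds named here, no measured pair shows this exact swap, so the expectation is indirect. The nearest guide is compound 3, which also has no (1,3-thiazol-2-yl)amino and carries an amide carbonyl in its side chain, at 0.507 h. A longer half-life, beyond the scatter, is therefore expected, with an estimated 5.7-fold higher number from compound 2 to compound 4 (0.76 log units; beyond the scatter). The estimated half-life of compound 4 is 0.4 h, with an expected range from 0.15 h to 1.2 h.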

Compound 4, half-life: < 0.0667 h
Compound 4 ended at the assay's limit (the forecaster's own chance of this, stated with the estimate: 5%); at least 5.9-fold (0.77 log units) between middle value and limit.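

In this assay compound 4 gives < 0.0667 h, which is a limit of the assay and not a number. Carbamoylmethyl in place of (1,3-thiazol-2-yl)amino on this saturated chain carbon gives an at least 1.0-fold lower number from compound 2 to compound 4 (0.02 log units; that floor lies within the scatter), so removing the thiazole-bearing group and adding this amide-bearing chain did not by itself give a longer half-life. The true size of the step cannot be read because compound 4 sits at the limit: the limit of < 0.0667 h in this assay, at which 1 of the 4 values shown sits.

Going by these compounds, it remains open whether an amine or a carboxylic acid on this same saturated chain carbon would bring the half-life clear of that limit. Also open is which part of the side chain of compound 3, which gives 0.507 h, accounts for its value.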